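Replacing 2,6-dichlorophenyl in compound 2

The source may hold more compounds than are shown below. What is called first, only, known or untested is meant among the compounds shown, and "the series" means these compounds.

Compound 1 `C[C@H]1CC[C@@H]2[C@@H](OC(=O)[C@]23CC(c2ccc(C#N)cc2)=NO3)[C@]2(C)C(=O)C=C[C@@]12O` measured at 1.17
Compound 2 `C[C@H]1CC[C@@H]2[C@@H](OC(=O)[C@]23CC(c2c(Cl)cccc2Cl)N(c2ccccc2)O3)[C@]2(C)C(=O)C=C[C@@]12O` measured at 4.45

In a physicochemical assay for lipophilicity (on this read-out higher numbers stand for higher lipophilicity and lower numbers for lower lipophilicity), compound 2 gives 4.45 and stands as the higher of the two measured compounds. Its distance from compound 1 at 1.17 lies well beyond the scatter. The two compounds differ in more than one place, so that gap does not isolate any single change.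

Compound 3 `COc1cccc(C2C[C@@]3(ON2c2ccccc2)C(=O)O[C@@H]2[C@H]3CC[C@H](C)[C@]3(O)C=CC(=O)[C@@]23C)c1` has not yet been measured. It carries 3-methoxyphenyl in place of 2,6-dichlorophenyl on a saturated ring carbon and otherwise matches compound 2. Going by the values given here, no measured pair shows this exchange on its own, so the size of the step in this assay remains a matter of judgement. A moderate fall beyond the scatter is expected, starting from compound 2 at 4.45 on this scale. The expected downward change is a number 0.75 log units lower from compound 2 to compound 3 (beyond the scatter) in this estimate. For compound 3 the estimated value is 3.7 with an expected range from 3.2 to 4.2 on the same scale.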

Compound 3, partition coefficient: 3.25
Beside the measured number, compound 3's estimate is 0.45 log units above it, within the range that was stated.
By their numbers in this assay, from the lowest: compound 1; then compound 3; then compound 2.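

In this assay, going by these compounds alone, 3-methoxyphenyl in place of 2,6-dichlorophenyl on a saturated ring carbon gives a number 1.20 log units lower from compound 2 to compound 3 (beyond the scatter), the first change at this position that can be read on its own, since the gap between compound 1 and compound 2 spanned more than one place. Both groups have 8 heavy atoms and one six-membered aromatic ring of carbon only, so this large step arises with the heavy-atom count and the ring type unchanged; the exchange removes 2 chlorine atoms and brings in 1 oxygen atom and 1 hydrogen-bond acceptor. Nothing available here accounts for the size of this step.

Because the two groups differ in more than one feature, this single step does not separate the loss of the two chlorine atoms from the arrival of the methoxy group, and unsubstituted phenyl or a single chlorine on the phenyl ring would be needed to divide it. Going by these compounds, how far the read-out would move with a carboxylic acid or an amine on this aromatic ring also remains open.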